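This account rests on a few compounds, and the source may have more. Where it says the series, first, only, none or still open, it means among the compounds named here.

Compound 1 `CC(C)c1ccc(-c2nc(SCc3cn(CC(=O)NC(=O)Nc4ccccn4)nn3)nc(Nc3cccc(Cl)c3)c2C#N)cc1`: 18000 nM
Compound 2 `Cc1ccc(Nc2nc(SCc3cn(CC(=O)NC(=O)Nc4ccccn4)nn3)nc(-c3ccc(C(C)C)cc3)c2C#N)cc1`: > 64000 nM

Among the compounds with values here, compound 1 is the only compound with a number in a functional assay on MCF7 cells (Homo sapiens) for inhibition, read by MTT assay, with a stated time of 72 h; a higher number here means a weaker inhibitor, a lower number a stronger inhibitor; the other value shown is a limit. In this assay compound 1 gives 18000 nM. For compound 2, this assay reports only a limit, > 64000 nM, at the limit of > 64000 nM in this assay, at which 1 of the 2 values shown sits.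

Compound 3 `Cc1ccccc1Nc1nc(SCc2cn(CC(=O)NC(=O)Nc3ccccn3)nn2)nc(-c2ccc(C(C)C)cc2)c1C#N` differs from compound 1 thus: 2-methylphenyl in place of 3-chlorophenyl on a nitrogen on an aromatic ring. Within the data shown here, the one measured step that bears on it is an at least 3.5-fold higher number from compound 1 to compound 2 (0.55 log units; beyond the scatter), which exchanged the same group on the same nitrogen for another methylphenyl. A step of like direction is therefore expected, a 2.5-fold higher number from compound 1 to compound 3 (0.40 log units; beyond the scatter). Compound 3 is estimated at 45000 nM, between 15000 nM and 130000 nM.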

Compound 3, half-maximal inhibitory concentration: > 64000 nM
Compound 3: only a limit was reported (the forecaster's own chance of this, stated with the estimate: 40%); at least 1.4-fold (0.15 log units) between middle value and limit.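

In this assay, 2-methylphenyl on this nitrogen gives an at least 3.5-fold higher number from compound 1 to compound 3 (0.55 log units; beyond the scatter), so a methylphenyl with its methyl placed differently from that in compound 2 also gives a higher number than 3-chlorophenyl. The step from compound 2 to compound 3 cannot be read, as both values are limits, and the two methyl placements stay unordered. Of the compounds shown, only compound 1 has a number in this assay, and the other two share one limit: the limit of > 64000 nM in this assay, at which 2 of the 3 values shown sit.

On these data alone, whether 2-chlorophenyl, 4-chlorophenyl or unsubstituted phenyl on this nitrogen would give a number remains open. So does how far the true values of compound 2 and compound 3 lie beyond their limit.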